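Phenyl in place of 3,4,5-trimethoxyphenyl on a long-chain amide

A few compounds are considered here, and "the series" means these few. Any claim that something is new, unique, unknown or untested is made for them only; others in the source may bear on it.

In a functional assay on cells (Homo sapiens) for antiproliferative activity, read by sulforhodamine B assay, with a stated time of 48 h (a higher number here means a weaker inhibitor, a lower number a stronger inhibitor), compound 1 (`CCCCCCCCCCCCNC(=O)[C@@H]1CSC(c2cc(OC)c(OC)c(OC)c2)N1`) gives 2100 nM, compound 2 (`CCCCCCCCCCCCCCNC(=O)[C@@H]1CSC(c2cc(OC)c(OC)c(OC)c2)N1`) gives 2000 nM and compound 3 (`CCCCCCCCCCCCCCCCNC(=O)[C@@H]1CSC(c2cc(OC)c(OC)c(OC)c2)N1`) gives 1800 nM. Compound 3 therefore stands level with the other two, with a 1.2-fold lower number from compound 1 to compound 3 (0.07 log units; within the scatter) and a 1.1-fold lower number from compound 2 to compound 3 (0.05 log units; within the scatter). The remaining step, a 1.1-fold lower number from compound 1 to compound 2 (0.02 log units; within the scatter), is just as small, and all three steps lie within the scatter.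

Compound 4 (`CCCCCCCCCCCCCCCCNC(=O)[C@@H]1CSC(c2ccccc2)N1`) keeps the chain of compound 3 but carries phenyl in place of 3,4,5-trimethoxyphenyl on a saturated ring carbon. Going by the values given here, all the measured steps concern the chain, and none touches this place, so they give no direct guide to the size of the change. With no measured change at this position, no step beyond the scatter is expected, although the uncertainty is wide. The expected change is a 1.2-fold lower number from compound 3 to compound 4 (0.08 log units; within the scatter). For compound 4, the estimated value is 1500 nM, with an expected range of 600 nM to 4000 nM.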

Compound 4, half-maximal inhibitory concentration: 1900 nM
Beside the measured number, compound 4's estimate is 1.3-fold (0.10 log units) below it; low and high end bracket the measured number.
By their numbers in this assay, from the lowest: compounds 3, 4, 2 and 1 (each within the scatter of the next).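

In this assay, going by these compounds alone, phenyl in place of 3,4,5-trimethoxyphenyl on a saturated ring carbon gives a 1.1-fold higher number from compound 3 to compound 4 (0.02 log units; within the scatter), the first measured step at this position. With the chain held the same, the group with 12 heavy atoms and 3 hydrogen-bond acceptors and the group with 6 heavy atoms and 0 hydrogen-bond acceptors therefore stand level in this pair, so the three methoxy groups taken together are not shown to matter here. No available evidence bears on why the two compounds stand level.

From the compounds shown here alone, whether phenyl also stands level with 3,4,5-trimethoxyphenyl on the shorter chains of compound 1 and compound 2 remains open. Also open, going by these compounds, is what a single methoxy group on the phenyl ring, a pyridine ring, or a cyclohexyl group would give on this saturated ring carbon.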